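The source may report more compounds than this note shows. Statements on the series, on what has been measured and on what is new or still open speak of the compounds shown alone.

Measured so far in an assay on HEK293 cells for antagonist activity at transient receptor potential cation channel subfamily V member 3 (Homo sapiens), read by FLIPR and calcium flux; on this read-out lower numbers stand for stronger inhibition and higher numbers for weaker inhibition:

Compound 1 `CC(O)(c1ccccn1)C1(c2ccc(Cl)c(Cl)c2)CCC1` gives 3400 nM.
Compound 2 `O[C@H](c1ccccn1)[C@]1(c2cccc(C(F)(F)F)c2)C[C@H](O)C1` gives 90 nM.
Compound 3 `O[C@H](c1ccccn1)[C@]1(c2ccc(C(F)(F)F)cc2)C[C@@H](O)C1` gives 1870 nM.

Of the three numbers, the value of compound 3 lies close to that of compound 1, a difference that stays within the scatter of this assay, and it stands far from the value of compound 2, which is much lower and clearly beyond the scatter. Compound 3 is therefore one of the two weaker members of this small set, with compound 2 alone at the strong end.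

Compound 4 `C[C@]1(O)C[C@@](c2ccc(C(F)(F)F)cc2)([C@H](O)c2ccccn2)C1` is the next compound to be measured in this assay. It differs from compound 3 by one change: methyl in place of hydrogen on a saturated ring carbon. Going by the values given here, no pair of measured compounds shows this kind of change, so there is no measured step to lean on. The expectation is that the step from compound 3 to compound 4 in this assay will be small, most likely within the scatter, with no clear direction. On that basis compound 4 is estimated at 1500 nM, with a plausible range from 400 nM to 6000 nM, which corresponds to an expected step of a 1.2-fold lower number from compound 3 to compound 4 (0.10 log units; within the scatter).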

Compound 4, antagonist equilibrium constant: 840 nM
The estimate for compound 4 lay 1.8-fold (0.25 log units) above the measured number; measured number inside the range.
By their numbers in this assay, from the lowest: compound 2; then compound 4; then compounds 3 and 1 (each within the scatter of the next).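

In this assay, going by these compounds alone, methyl in place of hydrogen on a saturated ring carbon of the four-membered ring gives a 2.2-fold lower number from compound 3 to compound 4 (0.35 log units; beyond the scatter), a modest step but the only measured step between compounds that differ in one place. It shows that this ring carbon, two ring bonds from the ring atom that bears a hydroxy(pyridin-2-yl)methyl group, can take one added carbon without any loss of inhibition; on this pair, the number moves towards stronger inhibition. Nothing measured among these compounds accounts for the size or direction of this step. From the compounds shown here alone, what remains open is whether the gain continues with a longer chain such as ethyl, or whether an amine or a fluorine atom on the same ring carbon would move the number the same way or the opposite way. Going by these compounds, it is also open whether the same methyl change would give a similar step on the core of compound 2, since one pair cannot show whether this step carries over to another core.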